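Nitro for cyano on a second core

The source may report more compounds than this note shows. Statements on the series, on what has been measured and on what is new or still open speak of the compounds shown alone.

Two cores are compared here. Compound 1 `CC(O)(CSc1ccc(S(F)(F)(F)(F)F)cc1)C(=O)Nc1ccc(C#N)c(C(F)(F)F)c1` and compound 2 `CC(O)(CSc1ccc(S(F)(F)(F)(F)F)cc1)C(=O)Nc1ccc([N+](=O)[O-])c(C(F)(F)F)c1` share one core; compound 3 `CC(O)(CSc1cccc(S(F)(F)(F)(F)F)c1)C(=O)Nc1ccc(C#N)cc1C(F)(F)F` and compound 4 `CC(O)(CSc1cccc(S(F)(F)(F)(F)F)c1)C(=O)Nc1ccc([N+](=O)[O-])cc1C(F)(F)F` share the other. The difference between the two cores is not broken down here. In a functional assay on DU-145 cells (Homo sapiens) for antiproliferative activity, read by propidium iodide staining, with a stated time of 96 h (on this read-out lower numbers stand for stronger inhibition and higher numbers for weaker inhibition), compound 1 gives 27900 nM, and compound 2 gives 13900 nM. The change between them is nitro in place of cyano on an aromatic carbon, and it made a 2.0-fold lower number from compound 1 to compound 2 (0.30 log units; within the scatter).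

In this assay compound 3 gives 37400 nM, close to compound 1 and beyond the scatter from compound 2. Compound 4 is not yet measured; it carries nitro in place of cyano on an aromatic carbon. This is the same kind of change as that from compound 1 to compound 2, not the same: there the nitro stands ortho to a trifluoromethyl group, here meta to a trifluoromethyl group.

For the measured compounds named here, the step from compound 3 to compound 4 is expected to be about a 2.0-fold lower number from compound 3 to compound 4 (0.30 log units; within the scatter), resting on the measured step of a 2.0-fold lower number from compound 1 to compound 2 (0.30 log units; within the scatter) and on the single pair behind it. Compound 4 is therefore estimated at 18700 nM in this assay, within 9000 nM to 40000 nM.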

Compound 4, half-maximal inhibitory concentration: 18900 nM
For compound 4 the middle estimate is 1.0-fold (0.00 log units) below the measured one; the range from low to high includes it.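

In this assay, nitro in place of cyano gives a 2.0-fold lower number from compound 3 to compound 4 (0.30 log units; within the scatter), and the step carries from one core to the other without a difference beyond the scatter: the same change on two cores in this assay, a 2.0-fold lower number (0.30 log units; within the scatter) from compound 1 to compound 2 and a 2.0-fold lower number (0.30 log units; within the scatter) from compound 3 to compound 4, 1.0-fold (0.01 log units) apart, within the scatter of two such steps

For the compounds shown here, each step lies within the scatter on its own, so this agreement shows only that the exchange stays within repeat variation on both cores, not that nitro gives a real gain on either. The result rests on two pairs in a single assay, the two cores differ in a way not broken down here, and nothing follows for other cores in the series.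

Nitrile and nitro are the only groups shown at this position, so it remains open whether an amine, a carboxylic acid or an amide there would move the number beyond the scatter. The thioether link is also constant across all four compounds, which leaves open how a sulfone or a longer chain in its place would read out.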